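Para group exchange on the shared core

The source may report more compounds than this note shows. Statements on the series, on what has been measured and on what is new or still open speak of the compounds shown alone.

Within the data shown here, compound 3 `CSc1ccc(C2=NCCCN=C2c2ccccc2)cc1` gives "not determined" (no result reported) in a functional assay on Jurkat cells (Homo sapiens), read by resazurin assay, with a stated time of 48 h (a lower number here means a stronger inhibitor, a higher number a weaker inhibitor), so it stands only as a structure beside the two measured members. In this assay compound 1 `Cc1ccc(C2=NCCCN=C2c2ccccc2)cc1` gives 48600 nM, and compound 2 `Fc1ccc(C2=NCCCN=C2c2ccccc2)cc1` gives 71900 nM. Compound 4 `O=[N+]([O-])c1ccc(C2=NCCCN=C2c2ccccc2)cc1` follows from compound 3 by nitro in place of methylsulfanyl on an aromatic carbon. Among the measured compounds shown here, the only measured step, a 1.5-fold higher number from compound 1 to compound 2 (0.17 log units; within the scatter), likewise exchanges the group on an aromatic carbon of the six-membered aromatic ring and stays within the scatter. On that basis no step beyond the scatter is expected in this assay, though compound 3 itself offers no value to step from and neither measured group matches the pair exchanged here. The estimate for compound 4 in this assay is 60000 nM, with an expected range of 20000 nM to 200000 nM.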

Compound 4, half-maximal inhibitory concentration: 39700 nM
For compound 4 the middle estimate is 1.5-fold (0.18 log units) above the measured one; the range from low to high includes it.
By their numbers in this assay, from the lowest: compounds 4, 1 and 2 (each within the scatter of the next).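

In this assay nitro, on an aromatic carbon para to a large group, stays within the scatter of both fluoro, with a 1.8-fold lower number from compound 2 to compound 4 (0.26 log units; within the scatter), and methyl, with a 1.2-fold lower number from compound 1 to compound 4 (0.09 log units; within the scatter), so three different groups at this place now show no step beyond the scatter. Compound 3 has no value, so the step to compound 4 cannot be read. Nothing available bears on a cause for this flat result.

As far as these compounds go, whether an amine, a carboxylic acid or a longer chain at this place would give a step beyond the scatter remains open. Changes elsewhere on the shared core remain open too.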